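This account rests on a few compounds, and the source may have more. Where it says the series, first, only, none or still open, it means among the compounds named here.

Working notes on the series. Compound 1 `O=C1C(NC2CCCC2)=CC(=O)c2c1nc1n2[C@H]2OC[C@@H](O)[C@H]2OC1` in a functional assay on ECa-109 cells for inhibition, with ECa-109 cell line (Homo sapiens) as the target, read by sulforhodamine B assay (on this read-out higher numbers stand for weaker inhibition and lower numbers for stronger inhibition), gives > 16000 nM, which is a limit of the assay. Compound 3 `O=C1C=C(NC2CCCC2)C(=O)c2c1nc1n2[C@H]2OC[C@@H](O)[C@H]2OC1` in this assay gives > 16000 nM, again a limit. Compound 3 and compound 1 have the same atoms joined differently; the difference between the two cores is not broken down here. Compound 2 `COc1ccccc1NC1=CC(=O)c2c(nc3n2[C@H]2OC[C@@H](O)[C@H]2OC3)C1=O` in this assay gives > 4000 nM, also a limit. The change 2-methoxyphenyl in place of cyclopentyl on an amine nitrogen makes the step that the two limits leave unreadable from compound 1 to compound 2, unreadable because the limit of > 16000 nM in this assay, at which 2 of the 3 values shown sit, and the limit of > 4000 nM in this assay, at which 1 of the 3 values shown sits, bound both ends. Compound 4 `COc1ccccc1NC1=CC(=O)c2nc3n(c2C1=O)[C@H]1OC[C@@H](O)[C@H]1OC3` carries the same change on the core of compound 3, (2-methoxyphenyl in place of cyclopentyl on an amine nitrogen). In this assay the step is expected to be a step that the limit leaves unreadable from compound 3 to compound 4, resting only on the unreadable a step that the two limits leave unreadable from compound 1 to compound 2 and on the limits of compound 3 and compound 2. Compound 4 is estimated at 20000 nM, most likely reported as a limit.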

Compound 4, half-maximal inhibitory concentration: > 4000 nM
Compound 4 gave a limit, no number; the forecaster's own chance of this, stated with the estimate: 85%; the middle value is on the limit's open side.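

Among the compounds shown here, compound 3 and compound 4 both stand only as limits of the assay, and no step between them can be read. The compounds shown leave open how strongly any of them acts in this assay, and whether the change from cyclopentylamino to (2-methoxyphenyl)amino or the difference between the two cores alters it.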